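The source may hold more compounds than are shown below. What is called first, only, known or untested is meant among the compounds shown, and "the series" means these compounds.

Measured in an ADME assay on HeLa cells (Homo sapiens) for cytotoxicity, read by MTT assay; on this read-out higher numbers stand for weaker inhibition and lower numbers for stronger inhibition:
- compound 1 `COC(=O)[C@@H]1CCCN1C(=O)CCC(=O)Oc1ccc(C[C@H]2C(=O)OC[C@@H]2Cc2ccc(OC)c(OC)c2)cc1OC`: 145000 nM
- compound 2 `COc1ccc(C[C@H]2COC(=O)[C@@H]2Cc2ccc(OCc3cn(-c4ccc(C)cc4)nn3)c(OC)c2)cc1OC`: >= 600000 nM (a limit of the assay)

Among the measured compounds shown here, compound 1 holds the only actual number in this assay, at 145000 nM. Compound 2 stands at >= 600000 nM, which is a limit and not a number.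

Compound 3 `COC(=O)[C@H](CC(C)C)NC(=O)CCC(=O)Oc1ccc(C[C@H]2C(=O)OC[C@@H]2Cc2ccc(OC)c(OC)c2)cc1OC` has not yet been measured. It keeps the core of compound 1 and carries (1-(methoxycarbonyl)-3-methylbutyl)amino in place of 2-(methoxycarbonyl)pyrrolidin-1-yl on a carbonyl carbon. For the measured compounds named here, no measured pair shows this change, and the expectation rests on compound 1 at 145000 nM alone. The step of a 1.0-fold higher number from compound 1 to compound 3 (0.01 log units; within the scatter) is expected to stay within the usual scatter, with neither direction favoured. For compound 3 the expected value is 150000 nM, with an estimated range from 60000 nM to 380000 nM.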

Compound 3, half-maximal inhibitory concentration: 53200 nM
For compound 3 the middle estimate is 2.8-fold (0.45 log units) above the measured one; measured number outside the range, below it.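

In this assay, among the compounds shown here, putting (1-(methoxycarbonyl)-3-methylbutyl)amino in place of 2-(methoxycarbonyl)pyrrolidin-1-yl on a carbonyl carbon gives a 2.7-fold lower number from compound 1 to compound 3 (0.44 log units; beyond the scatter), the first step that can be read at this position. The number therefore does respond to this group, if modestly, and the open-chain group with its amide hydrogen goes with the stronger inhibition on this read-out. Nothing measured here accounts for the step.

As far as these compounds go, the two groups differ at once in the ring, the amide hydrogen and the side chain, so which of these carries the step stays open. Also open, from the compounds shown here alone, is how a carboxylic acid in place of the methoxycarbonyl, or a shorter chain in place of the 3-methylbutyl part, would read in this assay.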